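A few compounds are considered here, and "the series" means these few. Any claim that something is new, unique, unknown or untested is made for them only; others in the source may bear on it.

Measured in a functional assay on HL-60 cells (Homo sapiens) for inhibition, read by MTT assay, with a stated time of 72 h; on this read-out higher numbers stand for weaker inhibition and lower numbers for stronger inhibition:
- compound 1 `CC(=O)c1ccc(N2CCN(C(=O)c3oc(C)nc3-c3ccccc3)CC2)cc1`: "not active" (no number reported)
- compound 2 `Cc1ccc(N2CCN(C(=O)c3oc(C)nc3-c3ccccc3)CC2)cc1`: > 1000 nM
- compound 3 `Cc1nc(-c2ccccc2)c(C(=O)N2CCN(c3cc(Cl)cc(Cl)c3)CC2)o1`: 41.8 nM

Compound 2 gave > 1000 nM, which is a limit of the assay and not a number. Within the data shown here, compound 1 gave no number either, so compound 3, at 41.8 nM, holds the only true number.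

Compound 4 `CC(=O)Nc1cccc(N2CCN(C(=O)c3oc(C)nc3-c3ccccc3)CC2)c1` keeps the shared core and differs in one place: 3-acetamidophenyl in place of 3,5-dichlorophenyl on an amine nitrogen in a ring. In short, 3-acetamidophenyl stands in place of 3,5-dichlorophenyl on an amine nitrogen in a ring.

Among the measured compounds shown here, one measured step bears on this change, at the same place: an at least 23-fold lower number from compound 2 to compound 3 (1.37 log units; beyond the scatter). It is large and beyond the scatter, and it came with the arrival of the 3,5-dichlorophenyl group that compound 4 now gives up. The entering group itself has not been tested in this assay. A large move towards a higher number is therefore expected, beyond the scatter, and it is estimated as a 14-fold higher number from compound 3 to compound 4 (1.16 log units; beyond the scatter). The expected value for compound 4 is 600 nM, with an estimated range of 100 nM to 3000 nM.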

Compound 4, half-maximal inhibitory concentration: 329 nM
The estimate for compound 4 lay 1.8-fold (0.26 log units) above the measured number, and the stated range covers the measured number.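

In this assay, the 3,5-dichlorophenyl group on the amine nitrogen in a ring can be exchanged for a group with an amide hydrogen and a carbonyl at a real cost, a 7.9-fold higher number from compound 3 to compound 4 (0.90 log units; beyond the scatter), yet the series still returns a true number. Set against the 4-methylphenyl group, the same entering group gives an at least 3.0-fold lower number from compound 2 to compound 4 (0.48 log units; beyond the scatter), so the aryl groups at this place now span three separate levels rather than a single large drop. Compound 2 holds a limit and not a number, and that step therefore has one open end: the limit of > 1000 nM in this assay, at which 1 of the 4 values shown sits.

From the compounds shown here alone, whether a single chlorine on the phenyl ring would be enough to hold the number of compound 3 stays open. So does the outcome for a free amine or a carboxylic acid at this place.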